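Swapping methoxy for fluoro on a kinase-type amide

The source may report more compounds than this note shows. Statements on the series, on what has been measured and on what is new or still open speak of the compounds shown alone.

Measured compounds in a functional assay on PC-3 cells (Homo sapiens) for cytotoxicity, read by MTT assay, with a stated time of 72 h; a lower number here means a stronger inhibitor, a higher number a weaker inhibitor:
- compound 1 `O=C(Nc1ccc(Oc2ccnc3[nH]ccc23)cc1)c1cc(-c2ccc(F)cc2)ncn1`: "not active" (no number reported)
- compound 2 `O=C(Nc1ccc(Oc2ccnc3[nH]ccc23)c(F)c1)c1cc(-c2ccccc2)ncn1`: 40 nM
- compound 3 `COc1ccc(-c2cc(C(=O)Nc3ccc(Oc4ccnc5[nH]ccc45)c(F)c3)ncn2)cc1`: 2570 nM

Compound 3 stands at the highest number of the two reported, the weakest of the compounds with a value. Its nearest neighbour is compound 2, and the step of a 64-fold higher number from compound 2 to compound 3 (1.81 log units; beyond the scatter) shows how much the methoxy group cost. Compound 1 gives no number at all in this assay.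

Compound 4 `O=C(Nc1ccc(Oc2ccnc3[nH]ccc23)c(F)c1)c1cc(-c2ccc(F)cc2)ncn1` differs from compound 3 by fluoro in place of methoxy on an aromatic carbon. Going by the values given here, only one measured step bears on this change: the one from compound 2 to compound 3, which was large. Fluoro adds only a single heavy atom where methoxy added two and an acceptor, so compound 4 is expected to sit well below compound 3, nearer to compound 2, yet compound 1 warns that a fluorinated phenyl can come with no measurable activity. The estimated step is a 13-fold lower number from compound 3 to compound 4 (1.11 log units; beyond the scatter). Compound 4 is therefore estimated at 200 nM, ranging from 40 nM to 1500 nM.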

Compound 4, half-maximal inhibitory concentration: "not active" (no number reported)
Nothing numeric was reported for compound 4; no gap can be computed for the estimate.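

In this assay compound 4 gives "not active" (no number reported) and so offers no number, which means no step can be read from compound 3 to compound 4. The compounds shown leave open how far 4-methoxyphenyl to 4-fluorophenyl shifts activity. Nothing shown explains this result.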